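The source may report more compounds than this note shows. Statements on the series, on what has been measured and on what is new or still open speak of the compounds shown alone.

Compound 1, `CC[C@H](C)[C@@H]1C(=O)N[C@H](C2Cc3ccccc3C2)C(=O)N1[C@@H](C(=O)N(C)C)c1cc(C)cnc1C`, gives 5 mL.min-1.g-1 in an in vitro ADME assay on microsomes from liver (Homo sapiens) for metabolic stability; a lower number here means slower removal, a higher number faster removal of the compound.
Compound 2, `CC[C@H](C)[C@@H]1C(=O)N[C@H](C2Cc3ccccc3C2)C(=O)N1[C@@H](C(=O)N1CCOCC1)c1ccc(C)nc1`, gives 3 mL.min-1.g-1 in this assay.

Of these two numbers, compound 2 has the lower one, but its gap to compound 1 lies within the usual scatter, so the two cannot be told apart. Compound 3, `CC[C@@H](C)[C@@H]1C(=O)N[C@H](C2Cc3ccccc3C2)C(=O)N1[C@@H](C(=O)N1CCOCC1)c1ccc(C)nc1`, is not yet measured. Compared with compound 2, (the two compounds have the same atoms and bonds and differ only in configuration as drawn: 1 of 4 stereo elements differ; a stereocentre at a saturated chain carbon is drawn S in compound 2 and R in compound 3). Among the measured compounds shown here, with no measured pair of this kind to draw on, no step beyond the scatter is expected in either direction. Compound 3 is therefore expected to give about 4 mL.min-1.g-1, between 1.5 mL.min-1.g-1 and 10 mL.min-1.g-1. That estimate means an expected step of a 1.3-fold higher number from compound 2 to compound 3 (0.12 log units; within the scatter).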

Compound 3, intrinsic clearance in microsomes: 4 mL.min-1.g-1
Estimate against measurement, compound 3: no gap at the digits printed; the range from low to high includes it.
By their numbers in this assay, from the lowest: compounds 2, 3 and 1 (each within the scatter of the next).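

Compounds 1 and 2 differ in more than one place, so they could not isolate any single change. This pair can, and it is a clean comparison because of one fact: the fact that compounds 2 and 3 differ only in the configuration as drawn. In this assay, drawing the stereocentre at the saturated chain carbon as R rather than S gives a 1.3-fold higher number from compound 2 to compound 3 (0.12 log units; within the scatter), so this configuration shows no measurable effect on clearance in this pair.

As far as these compounds go, whether the other stereo elements are equally silent remains open. So does the effect of a cyclohexyl group in place of the chain carrying this stereocentre.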